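The compounds below may be only part of what the source reports. "The series", "measured", "known", "first", "only" and "open" are said of these compounds alone.

Compound 1 `COc1ccc(C2CC(c3ccccc3)=NN2C(=O)c2ccc3c(c2)OCCO3)cc1` belongs to a small set of two measured compounds built on the same core. In a functional assay on WM 266-4 cells (Homo sapiens) for inhibition, read by MTT assay, with a stated time of 24 h (a lower number here means a stronger inhibitor of growth, a higher number a weaker inhibitor of growth), compound 1 gives 8370 nM. Its companion, compound 2 `COc1ccc(C2=NN(C(=O)C3COc4ccccc4O3)C(c3cccc(F)c3)C2)cc1`, gives 6720 nM in this assay, and the two numbers lie close together, within the usual scatter of this kind of measurement, so neither compound can be called the stronger or weaker inhibitor of growth on these data alone.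

The unmeasured compound 3 `O=C(c1ccc2c(c1)OCCO2)N1N=C(c2ccccc2)CC1c1ccc(F)cc1` differs from compound 1 in one place: fluoro in place of methoxy on an aromatic carbon. For the measured compounds named here, no measured pair shows this exact change, so there is no direct guide to its effect. With both measured compounds weak and the change small, the step from compound 1 to compound 3 is expected to be a 1.2-fold lower number from compound 1 to compound 3 (0.08 log units; within the scatter), not beyond the scatter. Compound 3 is therefore estimated to give 7000 nM in this assay, with a range from 2500 nM to 20000 nM.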

Compound 3, concentration for 50% growth inhibition: 5210 nM
Beside the measured number, compound 3's estimate is 1.3-fold (0.13 log units) above it, within the range that was stated.
By their numbers in this assay, from the lowest: compounds 3, 2 and 1 (each within the scatter of the next).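

Swapping 4-methoxyphenyl for 4-fluorophenyl gives a 1.6-fold lower number from compound 1 to compound 3 (0.21 log units; within the scatter) in this assay. For the compounds shown here, this is the first pair in the set that differs in one place only, so it is the first direct reading of this position, whereas compounds 1 and 2 could not be compared in this way. At this place on the aromatic ring, para to a large group, fluoro can stand in for methoxy with no change that can be told from the scatter, although nothing measured here bears on what lies behind this result.

On these data alone, whether an amine, a carboxylic acid or a longer chain at this place would move the number beyond the scatter remains open. A single pair also cannot show whether the same swap would read alike with other groups elsewhere on the shared core.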